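The source may hold more compounds than are shown below. What is called first, only, known or untested is meant among the compounds shown, and "the series" means these compounds.

In an in vitro functional assay on cells for agonist activity at Bombesin receptor subtype-3 (Homo sapiens), read by luminescence and calcium flux (a higher number here means that more compound is needed for the effect, a lower number that less compound is needed), the three measured compounds gave:

- compound 1 `CCCCc1cnc(C(CCC)Cc2ccc(-c3ccccc3C(=O)O)cc2)[nH]1`: 1180 nM
- compound 2 `O=C(O)c1ccccc1-c1ccc(CCc2ncc(C3CCCCC3)[nH]2)cc1`: 375 nM
- compound 3 `Cc1ccccc1Cc1cnc(CCc2ccc(-c3ccccc3C(=O)O)cc2)[nH]1`: 127 nM

Compound 3 holds the lowest number of the three. Its nearest neighbour is compound 2, and the step of a 3.0-fold lower number from compound 2 to compound 3 (0.47 log units; beyond the scatter) lies beyond the scatter. Compound 1 sits further away still, with a higher number than compound 3 by a gap that is also beyond the scatter.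

Compound 4 `O=C(O)c1ccccc1-c1ccc(CCc2ncc(Cc3ccccc3F)[nH]2)cc1` keeps the shared core of compound 3 and changes only one point on the benzyl group: fluoro in place of methyl on an aromatic carbon. The fluoro sits on an aromatic carbon of a six-membered aromatic ring of carbon only, ortho to a large group, where the methyl stood.

Only one step has been measured among these compounds, and it is of a different kind: from compound 2 to compound 3 an entire cyclohexyl was replaced by a 2-methylbenzyl. Going by the values given here, no measured step exchanges methyl for fluoro, so nothing here bears directly on the change to compound 4. A swap of one small atom for one small group on a ring that is already in place is expected to shift this assay little, so a step of a 1.3-fold higher number from compound 3 to compound 4 (0.13 log units; within the scatter) is estimated, within the scatter. Compound 4 is therefore expected to give about 170 nM, with a range from 55 nM to 520 nM.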

Compound 4, half-maximal effective concentration: 177 nM
Compound 4: the middle estimate sits 1.0-fold (0.02 log units) below what was measured, and the stated range covers the measured number.
By their numbers in this assay, from the lowest: compounds 3 and 4 (each within the scatter of the next); then compound 2; then compound 1.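

In this assay, going by these compounds alone, the first exchange of one small group for another at this place gives a 1.4-fold higher number from compound 3 to compound 4 (0.14 log units; within the scatter), so on an aromatic carbon ortho to a large group, methyl and fluoro cannot be told apart. The 2-fluorobenzyl group also keeps a clear distance from cyclohexyl, with a 2.1-fold lower number from compound 2 to compound 4 (0.33 log units; beyond the scatter), which stands alongside a 3.0-fold lower number from compound 2 to compound 3 (0.47 log units; beyond the scatter); among compounds 2, 3 and 4, then, both benzyl groups give a lower number than cyclohexyl, and the small group on the benzyl ring makes no difference beyond the scatter. The data shown offer no independent measurement that could explain either of these results.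

Two groups at this place are too few to show whether the position tolerates substituents in general, and a larger or different group, such as methoxy, chloro, trifluoromethyl or an amine, might behave differently. As far as these compounds go, it also remains open whether the same exchange of methyl for fluoro would be equally quiet on another carbon of that ring, or with the benzyl group replaced by a longer chain.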